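Estimating Cytotoxicity for an Unmeasured Amine Analogue

This account rests on a few compounds, and the source may have more. Where it says the series, first, only, none or still open, it means among the compounds named here.

Three compounds from this series have been examined in a toxicity assay on MDCK cells (Canis lupus familiaris) for cytotoxicity, read by crystal violet staining, with a stated time of 48 h; on this read-out higher numbers stand for lower toxicity in this test and lower numbers for higher toxicity in this test. Compound 1 `CCCCC(c1cc2ccc(C)cc2[nH]c1=O)N(Cc1ccc(F)cc1)Cc1ccc(C(C)C)cc1` reaches only the upper limit of this assay, at > 33000 nM, so no number is known for it. Compound 3 `CC(C)c1ccc2[nH]c(=O)c(CN(Cc3ccc(C(C)(C)C)cc3)C(C)c3ccc(F)cc3)cc2c1` gives 13100 nM in this assay. For compound 2 `Cc1ccc2[nH]c(=O)c(CN(Cc3ccc(OC(C)C)cc3)Cc3ccc(C(C)(C)C)cc3)cc2c1` this assay also reports a limit rather than a number, at > 5000 nM. Going by the values given here, compound 2 therefore stands on a limit alone, and one of the other two values shown is a limit as well, so no step between measured compounds can be drawn from these three.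

Compound 4 `Cc1ccc2[nH]c(=O)c(CN(Cc3ccc(C(C)(C)C)cc3)C(C)c3ccc(N(C)C)c(Cl)c3)cc2c1` is built from compound 2 by the change (1-(3-chloro-4-(dimethylamino)phenyl)ethyl in place of 4-isopropoxybenzyl on an amine nitrogen). Among the compounds with values here, with no measured step of this kind available, the author expects the change to carry no effect beyond the usual scatter, and estimates a step that the limit leaves unreadable from compound 2 to compound 4 for compound 4. Compound 4 is accordingly expected to give about 10000 nM in this assay, within a range from 3000 nM to 33000 nM.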

Compound 4, half-maximal cytotoxic concentration: 9800 nM
For compound 4 the middle estimate is 1.0-fold (0.01 log units) above the measured one; measured number inside the range.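

Going by these compounds alone, no step from compound 2 to compound 4 can be read, because compound 2 stands only on a limit: the limit of > 5000 nM in this assay, at which 1 of the 4 values shown sits. The compounds shown leave open whether 1-(3-chloro-4-(dimethylamino)phenyl)ethyl in place of 4-isopropoxybenzyl on an amine nitrogen shifts the half-maximal cytotoxic concentration at all, and in which direction.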